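Trifluoromethyl Replaced by Methoxy on a Benzyl Group

The source may hold more compounds than are shown below. What is called first, only, known or untested is meant among the compounds shown, and "the series" means these compounds.

Compound 1 `COc1ccc(Cn2cc(CNC(=O)c3cn(-c4ccccc4)nc3-c3ccc(F)cc3)nn2)cc1`: 3700 nM
Compound 2 `COc1ccc(-c2nn(-c3ccccc3)cc2C(=O)NCc2cn(Cc3ccc(C(F)(F)F)cc3)nn2)cc1`: > 100000 nM

Both compounds were tested in a functional assay on MIA PaCa-2 cells (Homo sapiens) for antiproliferative activity, read by sulforhodamine B assay, with a stated time of 48 h; a lower number here means a stronger inhibitor of growth, a higher number a weaker inhibitor of growth. Compound 1 gives 3700 nM. Compound 2 gives only a limit, > 100000 nM, which is not a number but the edge of what the measurement reports (the limit of > 100000 nM in this assay, at which 1 of the 2 values shown sits). For the measured compounds named here, compound 2 and compound 1 differ in two places, so no single step between them is computed; their two values show only that compound 1 is a measurable inhibitor of growth while compound 2 falls outside the range. Compound 3 `COc1ccc(Cn2cc(CNC(=O)c3cn(-c4ccccc4)nc3-c3ccc(OC)cc3)nn2)cc1` is not yet measured. It differs from compound 2 in one place: methoxy in place of trifluoromethyl on an aromatic carbon. Since compound 2 sits at the limit, any reported number for compound 3 would mean a step toward stronger inhibition of growth, and the step expected is an at least 12-fold lower number from compound 2 to compound 3 (1.09 log units; beyond the scatter). Compound 3 is expected to give 8000 nM, with a range from 2000 nM to 60000 nM.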

Compound 3, concentration for 50% growth inhibition: 2500 nM
Compound 3: the middle estimate sits 3.2-fold (0.51 log units) above what was measured, and the stated range covers the measured number.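

Compound 1 and compound 2 differ in two places, so neither place could be judged alone, but the benzyl group now can be: going from 4-(trifluoromethyl)benzyl to 4-methoxybenzyl gives an at least 40-fold lower number from compound 2 to compound 3 (1.60 log units; beyond the scatter) in this assay, which shows that the group at this position can decide whether growth inhibition is seen at all. Methoxy in place of fluoro on the other aromatic ring gives a 1.5-fold lower number from compound 1 to compound 3 (0.17 log units; within the scatter), so with 4-methoxybenzyl in place, that second change cannot be told apart from the scatter. Compound 2 gives a limit, not a number: the limit of > 100000 nM in this assay, at which 1 of the 3 values shown sits.

The compounds shown leave open how an amine or a carboxylic acid would behave in place of methoxy on the benzyl group. They also do not show why trifluoromethyl and methoxy differ so widely here.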